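The compounds below may be only part of what the source reports. "The series", "measured", "known", "first", "only" and "open" are said of these compounds alone.

Measured compounds:
compound 1 `CCC(C)(C)Cc1c[nH]c(CCc2ccc(-c3cccc(C)n3)cc2)n1` gives 102 nM in a functional assay on HEK293 cells for agonist activity at Bombesin receptor subtype-3 (Homo sapiens), read by luminescence and calcium flux, with a stated time of 10 min; a higher number here means that more compound is needed for the effect, a lower number that less compound is needed
compound 2 `CCC(C)(C)Cc1c[nH]c(CCc2ccc(-c3ccccc3C(=O)O)cc2)n1` gives 101 nM in this assay
compound 3 `CCC(C)(C)Cc1c[nH]c(CCc2ccc(-c3csnn3)cc2)n1` gives 104 nM in this assay

Compound 3 holds the highest of the three numbers, but the gaps to compound 1 and to compound 2 are both within the scatter, so no ordering among the three is claimed. The steps measured so far all exchange the group on the six-membered carbon ring of the shared core: a 1.0-fold lower number from compound 1 to compound 2 (0.00 log units; within the scatter), a 1.0-fold higher number from compound 1 to compound 3 (0.01 log units; within the scatter) and a 1.0-fold higher number from compound 2 to compound 3 (0.01 log units; within the scatter). None of these three exchanges moved the number beyond the scatter.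

Compound 4 `CCC(C)(C)Cc1c[nH]c(CCc2ccc(-n3cncn3)cc2)n1` is not yet measured. It differs from compound 3 as follows: 1H-1,2,4-triazol-1-yl in place of 1,2,3-thiadiazol-4-yl on an aromatic carbon. The three measured steps all bear on this change, as each swaps one ring group for another at the same place, and each was flat. No step beyond the scatter is therefore expected in this assay for compound 4, in either direction, and the expected step is a 1.0-fold higher number from compound 3 to compound 4 (0.00 log units; within the scatter). For compound 4 the estimated value is 105 nM, with an expected range from 50 nM to 220 nM.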

Compound 4, half-maximal effective concentration: 89 nM
Compound 4: the middle estimate sits 1.2-fold (0.07 log units) above what was measured, and the stated range covers the measured number.
By their numbers in this assay, from the lowest: compounds 4, 2, 1 and 3 (each within the scatter of the next).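

In this assay, the place para to a large group also accepts a ring attached through nitrogen, whereas the three earlier groups are all attached through carbon: a 1.2-fold lower number from compound 3 to compound 4 (0.07 log units; within the scatter) and a 1.1-fold lower number from compound 2 to compound 4 (0.05 log units; within the scatter) sit alongside a 1.1-fold lower number from compound 1 to compound 4 (0.06 log units; within the scatter) with no gap beyond the scatter. The direct exchange keeps the count of 5 heavy atoms and the single five-membered aromatic ring with 3 hetero atoms but replaces sulfur with a third nitrogen, and this change in ring atoms and attachment leaves the number flat. Nothing available on these compounds accounts for this flat result.

As far as these compounds go, whether any group at this place can move the number beyond the scatter remains open, since a small amine, a methoxy group or a plain hydrogen in place of the ring would test a far simpler substituent. From the compounds shown here alone, all four compounds also share the same 2,2-dimethylbutyl chain, so the response to a shorter chain there is unknown.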